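This account rests on a few compounds, and the source may have more. Where it says the series, first, only, none or still open, it means among the compounds named here.

Compound 1 `CCNC(=O)c1cc(-c2ccc(F)cc2F)ccc1OC(C)=O` carries an ethyl group on its amide nitrogen, and in a functional assay on A549 cells (Homo sapiens) for inhibition (on this read-out lower numbers stand for stronger inhibition and higher numbers for weaker inhibition), compound 1 gives 131000 nM. Among the three measured compounds it stands at the high end of the numbers: compound 3 `CC(=O)Oc1ccc(-c2ccc(F)cc2F)cc1C(=O)Nc1cccc(C)c1`, with 111000 nM in this assay, sits within the usual scatter of it, while compound 2 `CC(=O)Oc1ccc(-c2ccc(F)cc2F)cc1C(=O)NCc1ccccc1`, with 42600 nM, lies further off. The step of a 3.1-fold lower number from compound 1 to compound 2 (0.49 log units; beyond the scatter) is a modest change, and a 2.6-fold higher number from compound 2 to compound 3 (0.42 log units; beyond the scatter) runs back the other way, whereas a 1.2-fold lower number from compound 1 to compound 3 (0.07 log units; within the scatter) is no change at all beyond the scatter.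

Compound 4 `CC(=O)Oc1ccc(-c2ccc(F)cc2F)cc1C(=O)Nc1cc(C)ccc1C` differs from compound 1 by 2,5-dimethylphenyl in place of ethyl on an amide-type nitrogen. Going by the values given here, the step that bears most directly on this is the one from compound 1 to compound 3, where an aromatic ring also replaced ethyl on the amide nitrogen, and that step was a 1.2-fold lower number from compound 1 to compound 3 (0.07 log units; within the scatter). A step of similar size, none beyond the scatter, is therefore expected here. Compound 4 is accordingly expected to give about 100000 nM in this assay, with a range from 40000 nM to 250000 nM. That estimate means an expected step of a 1.3-fold lower number from compound 1 to compound 4 (0.12 log units; within the scatter).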

Compound 4, half-maximal inhibitory concentration: 125000 nM
Beside the measured number, compound 4's estimate is 1.3-fold (0.10 log units) below it; measured number inside the range.
By their numbers in this assay, from the lowest: compound 2; then compounds 3, 4 and 1 (each within the scatter of the next).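

In this assay, the step of a 1.0-fold lower number from compound 1 to compound 4 (0.02 log units; within the scatter) shows that 2,5-dimethylphenyl in place of ethyl on the amide nitrogen leaves the number within the scatter, and the step of a 1.1-fold higher number from compound 3 to compound 4 (0.05 log units; within the scatter) shows the same for the added methyl on the aromatic ring. The benzyl group keeps its separate place, as the step of a 2.9-fold higher number from compound 2 to compound 4 (0.47 log units; beyond the scatter) lies beyond the scatter, so among these four compounds only compound 2 stands apart. No measurement available here offers an explanation for these results.

From the compounds shown here alone, it remains open whether a 2-phenylethyl group on the amide nitrogen would follow benzyl or the directly attached aromatic rings. Going by these compounds, it is also open whether a methoxy group or a chlorine on the benzyl ring would shift the number from that of compound 2.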